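The compounds below may be only part of what the source reports. "The series", "measured", "known", "first", "only" and "open" are said of these compounds alone.

In an ADME assay on BHK-21 cells (Mesocricetus auratus) for cytotoxicity, read by MTT assay, with a stated time of 96 h (on this read-out lower numbers stand for higher toxicity in this test and higher numbers for lower toxicity in this test), the starting point is compound 1 `c1ccc(/N=N/N2CCCCC2)cc1`, which has no exact number. Compound 1 gives > 100000 nM, and this value is a limit. Its chloro analogue, compound 2 `Clc1ccc(/N=N/N2CCCCC2)cc1`, gives > 100000 nM, which is also a limit.

The compound not yet measured is compound 3 `O=[N+]([O-])c1cccc(/N=N/N2CCCCC2)c1`, which keeps the core of compound 1 but has nitro in place of hydrogen on an aromatic carbon.

Among the measured compounds shown here, the only measured step that bears on this change is a step that the two limits leave unreadable from compound 1 to compound 2, in which chloro replaces hydrogen on an aromatic carbon. It has no readable size, and the evidence amounts to the limit of > 100000 nM in this assay, at which 2 of the 2 values shown sit. The data therefore give no size to carry over to the nitro change, and no direction for it. On this basis, no step beyond the usual scatter is expected in this assay. The expected change is a number no higher from compound 1 to compound 3 (the limit leaves the size open). For compound 3 the estimated value is 100000 nM, with an expected range from 40000 nM to 150000 nM.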

Compound 3, half-maximal cytotoxic concentration: > 100000 nM
Compound 3: only a limit was reported; the forecaster's own chance of this, stated with the estimate: 70%; the middle value sits exactly at the limit.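

In this assay compound 3 gives > 100000 nM, which is a limit, so the step from compound 1 to compound 3 cannot be read. The compounds shown leave open whether chloro or nitro in place of hydrogen on an aromatic carbon changes the half-maximal cytotoxic concentration at all, since the evidence stops at: the limit of > 100000 nM in this assay, at which 3 of the 3 values shown sit.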